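Replacing 4-methoxyphenyl with 3-aminophenyl in compound 2

The source may report more compounds than this note shows. Statements on the series, on what has been measured and on what is new or still open speak of the compounds shown alone.

Compound 1 `COc1ccc(/C=C\c2ccc3c(c2)C(C)(C)CCC3(C)C)cc1N` (50000 nM)
Compound 2 `COc1ccc(/C=C\c2ccc3c(c2)C(C)(C)CCC3(C)C)cc1` (a limit: > 100000 nM)
Compound 3 `COc1ccc(/C=C/c2ccc3c(c2)C(C)(C)CCC3(C)C)cc1` (a limit: > 100000 nM)

In a functional assay on HL-60 cells (Homo sapiens), with a stated time of 48 h (on this read-out higher numbers stand for an effect only at larger amounts of compound and lower numbers for an effect already at smaller amounts), compound 2 gives no number, only a limit (> 100000 nM). Going by the values given here, the same holds for compound 3, so the series shows the limit of > 100000 nM in this assay, at which 2 of the 3 values shown sit, and leaves compound 1 as the only one with a number.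

Compound 4 `CC1(C)CCC(C)(C)c2cc(/C=C\c3cccc(N)c3)ccc21` carries a different aromatic group on the same core (3-aminophenyl in place of 4-methoxyphenyl on a double-bonded chain carbon bound to a double-bonded chain carbon). Among the compounds with values here, two measured steps bear on this change. The first is hydrogen in place of amino on an aromatic carbon, which gave an at least 2.0-fold higher number from compound 1 to compound 2 (0.30 log units; that floor lies within the scatter) and is a floor, not a full size. The second rests on the fact that compounds 2 and 3 differ only in the configuration as drawn and is a step that the two limits leave unreadable from compound 2 to compound 3 with no size to carry over.

Within the data shown here, compound 4 keeps an amino group, as compound 1 does, but loses the methoxy group, and no measured step isolates that loss. Compound 1, with its value (50000 nM), is therefore the closest guide. What is expected in this assay is a move to a lower number, estimated as an at least 2.2-fold lower number from compound 2 to compound 4 (0.34 log units; beyond the scatter) (a limit could again be reported). For compound 4 the estimated value is 45000 nM (expected range 10000 nM to 100000 nM).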

Compound 4, concentration for half-maximal activity: 10000 nM
Compound 4: middle estimate off by 4.5-fold (0.65 log units), on the high side, within the range that was stated.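

In this assay, the whole exchange at this place, on a double-bonded chain carbon bound to a double-bonded chain carbon, gives an at least 10-fold lower number from compound 2 to compound 4 (1.00 log units; beyond the scatter); this size is a floor, yet it lies beyond the scatter, which the floor for removing the amino group alone did not. Going by these compounds alone, the methoxy group can now be judged for the first time, with both ends of the step as real numbers and the amino group kept: removing the methoxy group gives a 5.0-fold lower number from compound 1 to compound 4 (0.70 log units; beyond the scatter), so the 3-aminophenyl group of compound 4 outdoes the methoxy-bearing aromatic group of compound 1. Compound 2 still stands only at a limit, so the full size of the exchange stays unknown: the limit of > 100000 nM in this assay, at which 2 of the 4 values shown sit.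

On these data alone, the step between the two double-bond configurations cannot be read, so whether configuration matters for an amino-bearing compound stays open: the fact that compounds 2 and 3 differ only in the configuration as drawn Also open is whether the amino group itself is required on the aromatic group of compound 4, or whether a hydroxyl or a carboxylic acid in its place would give a similar number.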